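The source may hold more compounds than are shown below. What is called first, only, known or untested is meant among the compounds shown, and "the series" means these compounds.

Compound 1 `CCOc1cc(NC(=O)NCc2cc(C)c(-c3cn(C)nc3C(F)(F)F)nn2)cc(C#N)n1` gives 35 nM in a functional assay on HFL1 cells for antagonist activity at sphingosine 1-phosphate receptor 2 (Homo sapiens), read by ELISA, with a stated time of 24 h, in the absence of a further agent; a lower number here means a stronger inhibitor, a higher number a weaker inhibitor.
Compound 2 `CCOc1cc(NC(=O)NCc2cc(C)c(-c3cn(C)nc3C(F)(F)F)nn2)cc(C)n1` gives 242 nM in this assay.

For the measured compounds named here, compound 2 has the higher of the two numbers, and the only measured step leads to it: a 6.9-fold higher number from compound 1 to compound 2 (0.84 log units; beyond the scatter). Compound 3 `CCOc1nc(C)cc(NC(=O)NCc2cc(C)c(-c3cn(C)nc3C(F)(F)F)nn2)c1C#N` keeps the methyl of compound 2 and adds a further group to the shared core: cyano in place of hydrogen on an aromatic carbon. Going by the values given here, the step of a 6.9-fold higher number from compound 1 to compound 2 (0.84 log units; beyond the scatter) shows a cyano group beating a methyl group, but no measured step tests a cyano group placed as in compound 3. A moderate drop in number is therefore expected, with wide uncertainty: a 2.4-fold lower number from compound 2 to compound 3 (0.38 log units; beyond the scatter). Compound 3 is estimated at 100 nM, between 30 nM and 400 nM.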

Compound 3, half-maximal inhibitory concentration: > 20000 nM
Compound 3 ended at the assay's limit (the forecaster's own chance of this, stated with the estimate: 5%); at least 200-fold (2.30 log units) between middle value and limit.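

On this aromatic carbon, ortho to an ethoxy group, cyano in place of hydrogen gives an at least 82-fold higher number from compound 2 to compound 3 (1.91 log units; beyond the scatter) in this assay. The value of compound 3 is a limit of the assay, not a number: the limit of > 20000 nM in this assay, at which 1 of the 3 values shown sits. The gain seen in a 6.9-fold higher number from compound 1 to compound 2 (0.84 log units; beyond the scatter) therefore does not carry over to this carbon, so what a cyano group does in this series depends on where it stands.

The compounds shown leave open whether this carbon tolerates any group other than hydrogen, such as a fluorine atom or a methyl group.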